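Compound 4: Dropping the Methoxy from Compound 3

A few compounds are considered here, and "the series" means these few. Any claim that something is new, unique, unknown or untested is made for them only; others in the source may bear on it.

In an ADME assay on HepG2 cells (Homo sapiens) for cytotoxicity, read by MTT assay, with a stated time of 24 h (on this read-out lower numbers stand for higher toxicity in this test and higher numbers for lower toxicity in this test), compound 1 (`CC1Cn2c(nc([N+](=O)[O-])c2-c2ccc(CO)cc2)O1`) gives > 500000 nM, which is a limit of the assay and not a number. Compound 2 (`CC1Cn2c(nc([N+](=O)[O-])c2-c2cccc(C#N)c2)O1`) likewise reaches only a limit, > 500000 nM. For the measured compounds named here, compound 3 (`COc1cccc(C#Cc2c([N+](=O)[O-])nc3n2CC(C)O3)c1`) gives 6410 nM, the only actual number so far. Compound 4 (`CC1Cn2c(nc([N+](=O)[O-])c2C#Cc2ccccc2)O1`) has not yet been measured. It carries hydrogen in place of methoxy on an aromatic carbon, meta to a large group (hydrogen in place of methoxy on an aromatic carbon). Going by the values given here, no measured pair shows this change, so the closest guide is compound 3 at 6410 nM, and no step beyond the usual scatter is expected in this assay. The expected step is a 1.2-fold higher number from compound 3 to compound 4 (0.07 log units; within the scatter). For compound 4 the estimated value is 7500 nM, with an expected range from 2500 nM to 25000 nM.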

Compound 4, half-maximal cytotoxic concentration: 5400 nM
Compound 4: middle estimate off by 1.4-fold (0.14 log units), on the high side; the range from low to high includes it.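

In this assay, hydrogen in place of methoxy on this aromatic carbon, meta to a large group, gives a 1.2-fold lower number from compound 3 to compound 4 (0.07 log units; within the scatter). For the compounds shown here, this is the first pair that differs in one place, and it shows that the methoxy makes no difference beyond the usual scatter between these two compounds. Nothing measured here gives a reason for this result.

Hydrogen is the only replacement shown at this position. As far as these compounds go, how an amine, a carboxylic acid or a longer chain in place of the methoxy would read in this assay remains open.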